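The source may hold more compounds than are shown below. What is called first, only, known or untested is meant among the compounds shown, and "the series" means these compounds.

In an ADME assay on BEAS-2B cells (Homo sapiens) for cytotoxicity, read by MTT assay, with a stated time of 72 h (a higher number here means a weaker inhibitor of growth, a lower number a stronger inhibitor of growth), the three measured compounds spread over a modest range. Compound 1 `CCCCOC(=O)Nc1ccc([Se]C#N)cc1` gives 12200 nM. Compound 2 `O=C(Nc1ccc([Se][Se]c2ccc(NC(=O)Oc3ccccc3)cc2)cc1)Oc1ccccc1` gives 8600 nM, a number that lies within the scatter of the number for compound 1. Compound 3 `N#C[Se]c1ccc(NC(=O)OCc2ccc([N+](=O)[O-])cc2)cc1` gives 32800 nM, which stands beyond the scatter above the number for compound 1, so that compound 1 sits second highest of the three and nearest to compound 2.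

Compound 4 `N#C[Se]c1ccc(NC(=O)Oc2ccccc2)cc1` has not been measured in this assay. It differs from compound 1 in one place: phenyl in place of butyl on an oxygen next to a carbonyl group. For the measured compounds named here, the phenyl carbamate is the same grouping that compound 2 carries, though compound 2 also differs from compound 4 in its selenium part, so no step between measured compounds isolates this change.

On that footing compound 4 is expected to land close to compound 1, with a step of a 1.1-fold lower number from compound 1 to compound 4 (0.04 log units; within the scatter) that is not expected to exceed the scatter. Compound 4 is estimated at 11000 nM, with a range from 5000 nM to 25000 nM.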

Compound 4, concentration for total growth inhibition: 38200 nM
The estimate for compound 4 lay 3.5-fold (0.54 log units) below the measured number; the measured number lies above the stated range.
By their numbers in this assay, from the lowest: compounds 2 and 1 (each within the scatter of the next); then compounds 3 and 4 (each within the scatter of the next).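

In this assay, the group on an oxygen next to a carbonyl group proves not to be indifferent: phenyl in place of butyl gives a 3.1-fold higher number from compound 1 to compound 4 (0.50 log units; beyond the scatter) and so moves the compound toward weaker inhibition of growth. For the compounds shown here, this is the first pair here that differs in one place, so it is the first direct reading of this position, which the earlier compounds could not give. No measured property of either group is at hand to account for the step.

As far as these compounds go, what remains open is whether the step follows from the aromatic ring itself or from the loss of the butyl chain, which a cyclohexyl group or a longer chain at this place would help to separate. A single pair also leaves open whether a benzyl group would follow phenyl or butyl.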